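Adding a fluoro to the chloro anilide of the mGluR5 series

This account rests on a few compounds, and the source may have more. Where it says the series, first, only, none or still open, it means among the compounds named here.

Two compounds of this series carry a shared core, seen in compound 1 `N#Cc1cc(F)cc(C(=O)Nc2ccccc2F)c1` and compound 2 `N#Cc1cc(F)cc(C(=O)Nc2cccc(Cl)c2)c1`. Among the compounds with values here, in an in vitro functional assay on HEK293-A cells for antagonist activity at metabotropic glutamate receptor 5 (Rattus norvegicus), read by calcium flux (a higher number here means a weaker inhibitor, a lower number a stronger inhibitor), compound 2 gives 45 nM, the only number obtained so far. For compound 1 the assay returns only a limit, > 30000 nM, so no number is available for it; the limit of > 30000 nM in this assay, at which 1 of the 2 values shown sits, marks where one of the two values sits. Within the data shown here, no pair of measured compounds differing in a single place exists, so no measured step can be drawn.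

Compound 3 `N#Cc1cc(F)cc(C(=O)Nc2cc(Cl)ccc2F)c1` has not yet been tested. It differs from compound 2 by fluoro in place of hydrogen on an aromatic carbon, the chloro group of compound 2 being kept. Compound 1 carries a fluoro at a comparable ring position without the chloro group and gives only a limit, which makes the outcome uncertain, but since the chloro group stays, a modest loss rather than a collapse is expected.

Compound 3 is therefore estimated at 150 nM, with a range from 30 nM to 2000 nM in this assay. The expected step from compound 2 to compound 3 is a 3.3-fold higher number from compound 2 to compound 3 (0.52 log units; beyond the scatter).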

Compound 3, half-maximal inhibitory concentration: 3780 nM
Beside the measured number, compound 3's estimate is 25-fold (1.40 log units) below it, outside the stated range (above it).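

On the ring that carries the chloro group, fluoro in place of hydrogen, ortho to a large group and para to the chloro group, proves to be far from a minor change: in this assay it gives an 84-fold higher number from compound 2 to compound 3 (1.92 log units; beyond the scatter), so keeping the chloro group does not protect the series from a large loss at this position. Read along the other single change, chloro in place of hydrogen still counts when the fluoro is present, with an at least 7.9-fold lower number from compound 1 to compound 3 (0.89 log units; beyond the scatter), which shows that the fluoro lowers the activity without abolishing the gain seen with the chloro group. For compound 1 the assay gives a limit and not a number, so the size of that second step is bounded on one side only: the limit of > 30000 nM in this assay, at which 1 of the 3 values shown sits.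

The compounds shown leave open whether this loss belongs to fluoro itself or would follow any group on this carbon, which a methyl group or a methoxy group there could separate. They also leave open whether the same fluoro would weigh as heavily with a bromo group or a methyl group in place of the chloro group.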